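Notes: 1,3-thiazol-5-yl in place of pyridin-3-yl

The source may report more compounds than this note shows. Statements on the series, on what has been measured and on what is new or still open speak of the compounds shown alone.

Measured so far:
Compound 1 `O=C(CCc1cc(Cl)ccc1NC(=O)c1ccccn1)c1ccccc1` gives 4500 nM in an assay on CHO cells for positive allosteric modulation of metabotropic glutamate receptor 5 (Homo sapiens), read by FLIPR; on this read-out lower numbers stand for an effect already at smaller amounts and higher numbers for an effect only at larger amounts of compound.
Compound 2 `O=C(Nc1ccc(Cl)cc1CN1C(=O)c2ccccc2C1=O)c1cccnc1` gives 35000 nM in this assay.
Compound 3 `O=C(Nc1ccc(Br)cc1CN1C(=O)c2ccc(F)cc2C1=O)c1ccccn1` gives 930 nM in this assay.

Compound 2 stands highest of the three numbers in this assay; its gap to compound 1 and its larger gap to compound 3 both lie beyond the scatter. Compound 4 `O=C(Nc1ccc(Cl)cc1CN1C(=O)c2ccccc2C1=O)c1cncs1` differs from compound 2 by 1,3-thiazol-5-yl in place of pyridin-3-yl on a carbonyl carbon. Among the measured compounds shown here, no measured pair shows this change, so its effect cannot be read from the data. The expected step is a 1.4-fold lower number from compound 2 to compound 4 (0.15 log units; within the scatter), which is taken as no movement beyond the scatter, with a slight lean toward a lower number. Compound 4 is therefore estimated at 25000 nM in this assay, within a range from 8000 nM to 80000 nM.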

Compound 4, half-maximal effective concentration: 1900 nM
For compound 4 the middle estimate is 13-fold (1.12 log units) above the measured one; the whole stated range lies above it.
By their numbers in this assay, from the lowest: compound 3; then compound 4; then compound 1; then compound 2.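

In this assay, among the compounds shown here, the change of 1,3-thiazol-5-yl in place of pyridin-3-yl on a carbonyl carbon gives an 18-fold lower number from compound 2 to compound 4 (1.27 log units; beyond the scatter) and is the first single-place step. The earlier compounds shown here differ in several places at once, so only now is this position seen to respond strongly to the ring held on the carbonyl carbon. Nothing available bears on the reason for this step.

Open, as far as these compounds go, is whether phenyl or 1,3-oxazol-5-yl on the same carbonyl carbon would move the number similarly. Also open, from the compounds shown here alone, is whether the step carries over to the core of compound 3.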